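Shortening the side chain ether in a benzimidazole-free description

This account rests on a few compounds, and the source may have more. Where it says the series, first, only, none or still open, it means among the compounds named here.

Measured so far:
compound 1, `CN1CCN(c2nc3ccccc3n2CCOc2ccccc2)CC1`: 6.9 nM
compound 2, `CCCCCCn1c(N2CCN(C)CC2)nc2ccccc21`: 26 nM
compound 3, `CCCCOCCn1c(N2CCN(C)CC2)nc2ccccc21`: 38 nM

All three share one core and differ only in the chain on the aromatic nitrogen. In a functional assay on ileum for inhibition of histamine H1 receptor (Cavia porcellus) (a higher number here means a weaker inhibitor, a lower number a stronger inhibitor), compound 3 gives the highest number of the three, though its gap to compound 2, a 1.5-fold higher number from compound 2 to compound 3 (0.16 log units; within the scatter), lies within the scatter, so the two cannot be ranked. Only compound 1 stands clearly apart: a 5.5-fold higher number from compound 1 to compound 3 (0.74 log units; beyond the scatter) and a 3.8-fold higher number from compound 1 to compound 2 (0.58 log units; beyond the scatter).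

Compound 4, `COCCn1c(N2CCN(C)CC2)nc2ccccc21`, is not yet measured. It is made from compound 3 by the change (hydrogen in place of propyl on a saturated chain carbon bound to an oxygen on a saturated carbon). For the measured compounds named here, no measured step removes carbon from the oxygen-bound chain, so the nearest guide is indirect: going from compound 1 to compound 3 replaced phenyl on that oxygen with butyl and raised the number, a 5.5-fold higher number from compound 1 to compound 3 (0.74 log units; beyond the scatter). Trimming the chain further is expected to move in the same direction, modestly, and it is estimated that a 1.8-fold higher number from compound 3 to compound 4 (0.27 log units; within the scatter). Compound 4 is therefore expected to give 70 nM, within 25 nM to 200 nM.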

Compound 4, half-maximal inhibitory concentration: 13 nM
Beside the measured number, compound 4's estimate is 5.4-fold (0.73 log units) above it; the whole stated range lies above it.
By their numbers in this assay, from the lowest: compounds 1, 4, 2 and 3 (each within the scatter of the next, the first and the last beyond it).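

In this assay, for the compounds shown here, this is the first step that shortens the chain on the oxygen itself, and cutting butoxy down to methoxy lowers the number beyond the scatter (a 2.9-fold lower number from compound 3 to compound 4 (0.47 log units; beyond the scatter)), so at this position the longer chain is not the better one. The small methyl on that oxygen also brings compound 4 level with the phenyl of compound 1 (a 1.9-fold higher number from compound 1 to compound 4 (0.28 log units; within the scatter)), and compound 4 cannot be ranked against compound 2 (a 2.0-fold lower number from compound 2 to compound 4 (0.30 log units; within the scatter)), so an aromatic ring on the oxygen is not required for a low number here. No measurement at hand gives a reason for the drop.

Going by these compounds, whether ethoxy or propoxy would fall between methoxy and butoxy remains open. So does whether a hydroxyl or an amine at the end of this chain would hold the number as low.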